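Fluoro for Methyl: Expected Effect on Cell Permeability

The source may report more compounds than this note shows. Statements on the series, on what has been measured and on what is new or still open speak of the compounds shown alone.

Measured in an ADME assay on Caco-2 cells (Homo sapiens) for permeability, in the apical to basolateral direction; a higher number here means that the compound crosses the layer faster, a lower number that the compound crosses the layer more slowly:
Compound 1, `Cc1c(NC(=O)c2ccc(C(C)(C)C)cc2)cccc1-c1ccnc2[nH]c(-c3ccc(C(=O)N4CCOCC4)cc3)nc12`: 0.02 10^-6 cm/s
Compound 2, `Cc1c(NC(=O)c2ccc(C(C)(C)C)cc2)cccc1-c1ccnc2[nH]c(-c3cnn(C)c3)nc12`: 0.6 10^-6 cm/s
Compound 3, `Cc1cc(-c2ccnc3[nH]c(-c4cnn(C)c4)nc23)ccc1CNC(=O)c1ccc(C(C)(C)C)cc1`: 0.2 10^-6 cm/s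

Compound 3 stands second highest of the three. Compound 2 is higher by a margin beyond the scatter, and compound 1 is lower by a wider margin, also beyond the scatter. The new compound 4, `Cn1cc(-c2nc3c(-c4ccc(CNC(=O)c5ccc(C(C)(C)C)cc5)c(F)c4)ccnc3[nH]2)cn1`, differs from compound 3 by fluoro in place of methyl on an aromatic carbon, on an aromatic carbon of a six-membered aromatic ring of carbon only, ortho to a large group and meta to a large group. Among the measured compounds shown here, no measured pair shows this change, so there is no step to lean on. A change this small is expected to move this assay no further than the scatter, in either direction. Compound 4 is therefore estimated at 0.2 10^-6 cm/s, within 0.07 10^-6 cm/s to 0.6 10^-6 cm/s, an expected step of no change at the digits printed from compound 3 to compound 4 (within the scatter).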

Compound 4, apparent permeability: 0.4 10^-6 cm/s
For compound 4 the middle estimate is 2.0-fold (0.30 log units) below the measured one; the range from low to high includes it.
By their numbers in this assay, from the lowest: compound 1; then compounds 3, 4 and 2 (each within the scatter of the next, the first and the last beyond it).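

Fluoro in place of methyl on this aromatic carbon, ortho to a large group and meta to a large group, gives in this assay a 2.0-fold higher number from compound 3 to compound 4 (0.30 log units; within the scatter). At this position, then, the two groups cannot be told apart in this read-out. Nothing measured here explains that result.

As far as these compounds go, whether a chloro, a methoxy or an amine on the same carbon would also stay within the scatter remains open. So does whether fluoro in place of the methyl of compound 2 would give a similar result.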